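This account rests on a few compounds, and the source may have more. Where it says the series, first, only, none or still open, it means among the compounds named here.

Working notes on the series. Compound 1 `COc1ccc(C2CC(c3ccccc3)=NN2C2=NC(=O)/C(=C3\C(=O)Nc4ccccc43)S2)cc1` gives 2000 nM in a functional assay on cells (Melanoma cell, Homo sapiens) for cytotoxicity, read by sulforhodamine B assay, with a stated time of 48 h; a higher number here means a weaker inhibitor of growth, a lower number a stronger inhibitor of growth. For the measured compounds named here, compound 2 `COc1ccc(C2=NN(C3=NC(=O)/C(=C4\C(=O)Nc5ccccc54)S3)C(c3ccc(OC)cc3)C2)cc1` gives 100000 nM in this assay, the higher of the two numbers so far; the only measured step, a 50-fold higher number from compound 1 to compound 2 (1.70 log units; beyond the scatter), adds a methoxy on an aromatic carbon. Compound 3 `COc1ccc(C2CC(c3ccc4ccccc4c3)=NN2C2=NC(=O)/C(=C3\C(=O)Nc4ccccc43)S2)cc1` carries naphthalen-2-yl in place of 4-methoxyphenyl on a carbon with a double bond to nitrogen. Going by the values given here, that step removes the methoxy whose addition weakened compound 2, so a return toward lower numbers is expected, though the naphthalen-2-yl itself has no precedent here. Compound 3 is estimated at 5000 nM, range 1000 nM to 50000 nM. The expected step is a 20-fold lower number from compound 2 to compound 3 (1.30 log units; beyond the scatter).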

Compound 3, concentration for 50% growth inhibition: 4800 nM
For compound 3 the middle estimate is 1.0-fold (0.02 log units) above the measured one; the range from low to high includes it.
By their numbers in this assay, from the lowest: compound 1; then compound 3; then compound 2.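

At the carbon with a double bond to nitrogen, naphthalen-2-yl is far better accepted than 4-methoxyphenyl, with a 21-fold lower number from compound 2 to compound 3 (1.32 log units; beyond the scatter) in this assay. Set against phenyl, the same group gives a 2.4-fold higher number from compound 1 to compound 3 (0.38 log units; beyond the scatter), a modest step, so a second fused aromatic ring costs far less here than the added methoxy did. No measurement offers an explanation for either step. Still open, going by these compounds, is whether an amine or a carboxylic acid on the phenyl at this position would be accepted, and how the shared 4-methoxyphenyl on the other ring carbon contributes.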